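A few compounds are considered here, and "the series" means these few. Any claim that something is new, unique, unknown or untested is made for them only; others in the source may bear on it.

Measured compounds in this series:
compound 1, `COc1ccc(Cn2cc[nH]c2=S)cc1Br` — 83200 nM
compound 2, `COc1ccc(Cn2cc[nH]c2=S)cc1[N+](=O)[O-]` — 355000 nM

Both numbers come from an assay on isolated protein for inhibition of Dopamine beta-hydroxylase (Rattus norvegicus); on this read-out higher numbers stand for weaker inhibition and lower numbers for stronger inhibition. Among the compounds with values here, compound 2 stands highest of the two measured values; its nearest neighbour is compound 1, and the only measured step, a 4.3-fold higher number from compound 1 to compound 2 (0.63 log units; beyond the scatter), separates them and lies beyond the scatter.

Compound 3, `COc1ccc(Cn2cc[nH]c2=S)cc1C`, is not yet measured. It differs from compound 2 by methyl in place of nitro on an aromatic carbon; the change sits ortho to a methoxy group and meta to a group of 7 heavy atoms, on the same aromatic carbon where compound 1 carries bromo.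

Within the data shown here, the one measured step that bears on this position is a 4.3-fold higher number from compound 1 to compound 2 (0.63 log units; beyond the scatter), a modest rise in the number when nitro replaced bromo. Going from nitro to methyl on that carbon is therefore expected to run the other way, toward the value of compound 1, as a modest step downward rather than none. The expected step is a 3.6-fold lower number from compound 2 to compound 3 (0.55 log units; beyond the scatter). For compound 3 the estimate in this assay is 100000 nM, with a range from 30000 nM to 330000 nM.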

Compound 3, half-maximal inhibitory concentration: 69200 nM
Compound 3: middle estimate off by 1.4-fold (0.16 log units), on the high side, and the stated range covers the measured number.
By their numbers in this assay, from the lowest: compounds 3 and 1 (each within the scatter of the next); then compound 2.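

In the terms of this assay (methyl against nitro: a 5.1-fold lower number from compound 2 to compound 3 (0.71 log units; beyond the scatter); methyl against bromo: a 1.2-fold lower number from compound 1 to compound 3 (0.08 log units; within the scatter)), this aromatic carbon now carries two groups that cannot be told apart, methyl and bromo, and one that stands apart, nitro. The earlier pair could not show which of its two groups was out of line, whereas compound 2 now reads as the weakest of the three, with its steps to both others beyond the scatter, and compound 1 and compound 3 sit together within the scatter. Nothing at hand explains why nitro separates from the other two groups.

Still open, from the compounds shown here alone, is how the reading behaves with other groups on the same carbon: a hydroxyl, an amine, a carboxylic acid or a longer chain such as propyl would show whether the level shared by methyl and bromo is the best this position gives or merely one point in a wider range. Also open, going by these compounds, is whether the gap between nitro and methyl persists when the methoxy group is exchanged for a hydroxyl or an ethoxy group.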